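The source may report more compounds than this note shows. Statements on the series, on what has been measured and on what is new or still open speak of the compounds shown alone.

Within the data shown here, compound 3 `O=C(O)C[C@@H](NC(=O)[C@@H]1CCN1S(=O)(=O)c1cc(Cl)cc(Cl)c1)c1ccc(OC2CCCC2)cc1` stands at the strongest end of the three values so far in an assay on RPMI-8866 cells for inhibition of integrin alpha-4/beta-1 (Homo sapiens); on this read-out lower numbers stand for stronger inhibition and higher numbers for weaker inhibition: compound 3 gives 0.5 nM, compound 1 `C/C=C/[C@@H](CC(=O)O)NC(=O)[C@@H]1CCCN1S(=O)(=O)c1cc(Cl)cc(Cl)c1` gives 13 nM, and compound 2 `CC(C)[C@H](CC(=O)O)NC(=O)[C@@H]1CCCN1S(=O)(=O)c1cc(Cl)cc(Cl)c1` gives 362 nM, each gap beyond the scatter. Compound 4 `O=C(O)C[C@@H](NC(=O)[C@@H]1CCN1S(=O)(=O)c1cc(Cl)cc(Cl)c1)c1ccc(OCF)cc1` differs from compound 3 only in the change (fluoromethyl in place of cyclopentyl on an oxygen on an aromatic ring); the same difference, cut one bond further out, reads cyclopentyloxy to fluoromethoxy. Among the measured compounds shown here, no measured step touches this position. For the measured compounds named here, the single step measured, a 28-fold higher number from compound 1 to compound 2 (1.44 log units; beyond the scatter), sits on the amide-type nitrogen and shows only that this assay can move far on a small change in one side chain; it gives no direction for the aryl ether of compound 3. With no anchor, the estimate for compound 4 rests on the size of the change alone: a group of five heavy atoms with a ring leaves and a group of two heavy atoms enters, so a weaker number is expected, a 20-fold higher number from compound 3 to compound 4 (1.30 log units; beyond the scatter), with wide uncertainty. Compound 4 is therefore estimated at 10 nM, expected between 1.5 nM and 70 nM.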

Compound 4, half-maximal inhibitory concentration: 0.72 nM
The estimate for compound 4 lay 14-fold (1.14 log units) above the measured number, outside the stated range (below it).
By their numbers in this assay, from the lowest: compounds 3 and 4 (each within the scatter of the next); then compound 1; then compound 2.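

In this assay, fluoromethyl in place of cyclopentyl on an oxygen on an aromatic ring gives a 1.4-fold higher number from compound 3 to compound 4 (0.16 log units; within the scatter), so this pair reads alike although the five-membered carbon ring is gone and the group carries fewer heavy atoms. The earlier compounds shown here gave no reading at this position; this pair shows that, on this core, the cyclopentyl ring is not required for a value at the level of compound 3. No supporting measurement accounts for this result.

On these data alone, a plain methyl on the same oxygen would show whether the fluorine of compound 4 counts for anything, and it remains open whether this single pair extends to other groups. An amine or a carboxylic acid at the end of a longer chain on that oxygen remains an untested kind of change in the compounds shown.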